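Phenyl in place of methyl on compound 2

A few compounds are considered here, and "the series" means these few. Any claim that something is new, unique, unknown or untested is made for them only; others in the source may bear on it.

Going by the values given here, compound 2 `Cc1ccc(CN2CCC(Cn3c(=O)oc4ccccc43)CC2)cc1` gives 2.9 nM in an assay on membranes from liver for displacement of a labelled ligand from Sigma non-opioid intracellular receptor 1 (Rattus norvegicus) (a higher number here means a weaker inhibitor, a lower number a stronger inhibitor), one of two numbers measured so far and within the scatter of the other. Compound 1 `O=c1oc2ccccc2n1CC1CCN(Cc2ccc(F)cc2)CC1` gives 3.9 nM, and the step of a 1.3-fold lower number from compound 1 to compound 2 (0.13 log units; within the scatter) lies within the scatter. Compound 3 `O=c1oc2ccccc2n1CC1CCN(Cc2ccc(-c3ccccc3)cc2)CC1` carries phenyl in place of methyl on an aromatic carbon. Among the compounds with values here, no measured step exchanges methyl for phenyl; the only step at this aromatic carbon, a 1.3-fold lower number from compound 1 to compound 2 (0.13 log units; within the scatter), shows that two different groups there leave the number unchanged beyond the scatter. The expected step is therefore a 1.7-fold higher number from compound 2 to compound 3 (0.24 log units; within the scatter), with no direction beyond the scatter claimed. Compound 3 is estimated at 5 nM, in a range from 1.5 nM to 20 nM.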

Compound 3, inhibition constant: 394 nM
Beside the measured number, compound 3's estimate is 79-fold (1.90 log units) below it; measured number above the stated range.
By their numbers in this assay, from the lowest: compounds 2 and 1 (each within the scatter of the next); then compound 3.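

In this assay this aromatic carbon proves sensitive to its group: phenyl in place of methyl gives a 140-fold higher number from compound 2 to compound 3 (2.13 log units; beyond the scatter), and phenyl in place of fluoro gives a 100-fold higher number from compound 1 to compound 3 (2.00 log units; beyond the scatter). The tolerance seen between methyl and fluoro therefore does not extend to phenyl. No measurement on hand bears on the reason for this loss.

Still open, from the compounds shown here alone, is whether a group such as ethyl, methoxy or cyclohexyl at this carbon stays close to compound 2 or falls toward compound 3. Also open, going by these compounds, is whether phenyl costs as much elsewhere on this aromatic ring.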